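Cytotoxicity notes: carbamoyl to fluoro on the anilide ring

The source may hold more compounds than are shown below. What is called first, only, known or untested is meant among the compounds shown, and "the series" means these compounds.

Compound 1, `CC(C)n1ncc2c(C(=O)Nc3cccc(C(N)=O)c3)cc(-c3cccs3)nc21`: in an ADME assay on LLC-MK2 cells (Macaca mulatta) for cytotoxicity, read by spectrophotometry and crystal violet staining, with a stated time of 4 days (a lower number here means that less compound is tolerated, a higher number that more compound is tolerated), compound 1 gives 25000 nM.
Compound 2, `CC(C)n1ncc2c(C(=O)Nc3cccc(F)c3)cc(-c3cccs3)nc21`: compound 2 gives > 200000 nM, which is a limit of the assay.
Compound 3, `CC(C)n1ncc2c(C(=O)Nc3cc(C(N)=O)ccc3F)cc(-c3cccs3)nc21`: compound 3 gives 25000 nM.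

Compound 4, `CC(C)n1ncc2c(C(=O)Nc3cc(F)ccc3F)cc(-c3cccs3)nc21`, is not yet measured in this assay. The change made in it is fluoro in place of carbamoyl on an aromatic carbon. The same kind of change was made as fluoro in place of carbamoyl on an aromatic carbon, where the step was an at least 8.0-fold higher number from compound 1 to compound 2 (0.90 log units; beyond the scatter), with compound 2 sitting at the limit of > 200000 nM in this assay, at which 1 of the 3 values shown sits. The two places are not the same word for word: in compound 3 the carbon that carries the change is also para to a fluoro group, which compound 1 lacks. The two cores differ by fluoro in place of hydrogen on an aromatic carbon, a change that gave no change at the digits printed from compound 1 to compound 3 (within the scatter).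

Resting on the step from compound 1 to compound 2, an at least 8.0-fold higher number from compound 1 to compound 2 (0.90 log units; beyond the scatter), and on compound 3 standing at 25000 nM, a step of about an 8.0-fold higher number from compound 3 to compound 4 (0.90 log units; beyond the scatter) is expected for compound 4. Compound 4 is therefore estimated at 200000 nM, with a range from 60000 nM to 600000 nM, and the assay may well report only a limit for compound 4.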

Compound 4, half-maximal cytotoxic concentration: 100000 nM
Compound 4: the middle estimate sits 2.0-fold (0.30 log units) above what was measured, within the range that was stated.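

In this assay, fluoro in place of carbamoyl raises the number again on the core carrying the extra fluoro group, a 4.0-fold higher number from compound 3 to compound 4 (0.60 log units; beyond the scatter), so the direction of the change carries across these two cores: the same change on two cores in this assay, an at least 8.0-fold higher number (0.90 log units; beyond the scatter) from compound 1 to compound 2 and a 4.0-fold higher number (0.60 log units; beyond the scatter) from compound 3 to compound 4; the limit leaves it open whether they differ

Compound 2 stands at a limit of the assay and not at a number, so the size of the change on the core of compound 1 is unknown, and a matching size on the two cores is not shown: the limit of > 200000 nM in this assay, at which 1 of the 4 values shown sits.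

Fluoro in place of hydrogen, read on the other pair as an at least 2.0-fold lower number from compound 2 to compound 4 (0.30 log units; that floor lies within the scatter), likewise cannot be separated from its earlier counterpart: the same change on two cores in this assay, no change at the digits printed (within the scatter) from compound 1 to compound 3 and an at least 2.0-fold lower number (0.30 log units; that floor lies within the scatter) from compound 2 to compound 4; the limit leaves it open whether they differ

On these data alone, the whole swap to the 2,5-difluorophenyl group gives a 4.0-fold higher number from compound 1 to compound 4 (0.60 log units; beyond the scatter), but whether the rise follows from losing carbamoyl in general or from fluoro in particular stays open, as a nitrile or a carboxylic acid in that place would test. Within the data shown here, only two pairs bear on this change, so its behaviour with chloro in place of the extra fluoro group also remains open.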